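From a 3-Methylbut-2-en-1-yl Ether to an Acetate

This account rests on a few compounds, and the source may have more. Where it says the series, first, only, none or still open, it means among the compounds named here.

Compound 1, `COc1ccc(Cc2coc3cc(O)cc(O)c3c2=O)cc1`: in a functional assay on H9c2 cells (Mus musculus) for cytotoxicity against H9c2 (Rattus norvegicus), read by MTT assay, with a stated time of 24 h (on this read-out lower numbers stand for an effect already at smaller amounts and higher numbers for an effect only at larger amounts of compound), compound 1 gives > 100000 nM, which is a limit of the assay rather than a number.
Compound 2, `COc1ccc(Cc2coc3cc(OCCCl)cc(O)c3c2=O)cc1`: in this assay compound 2 gives > 100000 nM, also a limit.
Compound 3, `COc1ccc(Cc2coc3cc(OCC=C(C)C)cc(O)c3c2=O)cc1`: in this assay compound 3 gives > 100000 nM, again a limit.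

Compound 3 therefore stands only at a limit, as do the other two measured compounds, all three sitting at the limit of > 100000 nM in this assay, at which 3 of the 3 values shown sit. The step that the two limits leave unreadable from compound 1 to compound 2 and the step that the two limits leave unreadable from compound 1 to compound 3 cannot be read in size, and the same holds for a step that the two limits leave unreadable from compound 2 to compound 3. Compound 4, `COc1ccc(Cc2coc3cc(OC(C)=O)cc(O)c3c2=O)cc1`, differs from compound 3 by acetyl in place of 3-methylbut-2-en-1-yl on an oxygen on an aromatic ring. Among the compounds with values here, no measured step gives a readable size that bears on this change; every step here is hidden by limits. The most the three values support is that three different groups on this oxygen have all left the read-out at the limit, so the expected outcome for compound 4 is no measurable effect within the tested range rather than a step of any size, a step that the limit leaves unreadable from compound 3 to compound 4. Compound 4 is estimated at 150000 nM, with a range from 50000 nM to 500000 nM, and is most likely to be reported once more only as a limit.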

Compound 4, half-maximal effective concentration: > 100000 nM
Compound 4 was reported as a limit; the forecaster's own chance of this, stated with the estimate: 85%; the middle value does not contradict the limit.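

No step from compound 1, compound 2 or compound 3 to compound 4 can be read in size, because all four compounds stand at a limit rather than a number: the limit of > 100000 nM in this assay, at which 4 of the 4 values shown sit.

The compounds shown leave open whether any group on this oxygen on the aromatic ring can bring a measurable effect in this assay.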